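From thiophen-3-yl to 1H-1,2,3-triazol-1-yl on a shared core

This account rests on a few compounds, and the source may have more. Where it says the series, first, only, none or still open, it means among the compounds named here.

Measured so far in an assay on microsomes from intestine for inhibition of acyl-CoA:cholesterol acyltransferase (Oryctolagus cuniculus); on this read-out lower numbers stand for stronger inhibition and higher numbers for weaker inhibition:
- compound 1 `O=C(Nc1c(F)cc(F)cc1F)N(Cc1ccc(-c2ccsc2)cc1)C1CCCCCC1` gives 23 nM
- compound 2 `Cc1cc(C)c(NC(=O)N(Cc2ccc(-c3ccsc3)cc2)C2CCCCCC2)c(C)c1` gives 19 nM

Compound 2 shows the lowest of the two numbers, yet the step of a 1.2-fold lower number from compound 1 to compound 2 (0.08 log units; within the scatter) lies within the scatter, so no order between the two is implied. Compound 3 `Cc1cc(C)c(NC(=O)N(Cc2ccc(-n3ccnn3)cc2)C2CCCCCC2)c(C)c1` differs from compound 2 by 1H-1,2,3-triazol-1-yl in place of thiophen-3-yl on an aromatic carbon. Within the data shown here, the only measured step concerns the group on the amide-type nitrogen, not this place, so no measured step bears on the change and the expectation is uncertain. Compound 3 is estimated at 50 nM, with a range from 12 nM to 250 nM. That estimate corresponds to an expected step of a 2.6-fold higher number from compound 2 to compound 3 (0.42 log units; beyond the scatter).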

Compound 3, half-maximal inhibitory concentration: 42 nM
The estimate for compound 3 lay 1.2-fold (0.08 log units) above the measured number; the measured number falls inside the stated range.
By their numbers in this assay, from the lowest: compounds 2, 1 and 3 (each within the scatter of the next, the first and the last beyond it).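

Among these compounds, the first measured change at this aromatic carbon, para to a large group, shows that the position is sensitive to which five-membered aromatic ring sits there: 1H-1,2,3-triazol-1-yl in place of thiophen-3-yl gives a 2.2-fold higher number from compound 2 to compound 3 (0.34 log units; beyond the scatter), a modest weakening of inhibition. The two rings have the same number of heavy atoms but differ in their hetero atoms, so this step is not a change in heavy-atom count. No available measurement explains the step.

As far as these compounds go, it remains open whether a phenyl ring or a dimethylamino group here would behave more like thiophen-3-yl or 1H-1,2,3-triazol-1-yl. From the compounds shown here alone, it also remains open whether the step would be similar with 2,4,6-trifluorophenyl on the amide-type nitrogen.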